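The source may report more compounds than this note shows. Statements on the series, on what has been measured and on what is new or still open speak of the compounds shown alone.

Compound 1 `O=C(NCCCCC(c1ccc(F)cc1)c1ccc(F)cc1)Nc1ccc([N+](=O)[O-])cc1`: 6470 nM
Compound 2 `Nc1ccc(NC(=O)NCCCCC(c2ccc(F)cc2)c2ccc(F)cc2)cc1`: > 20000 nM (a limit)
Compound 3 `Cc1cccc(NC(=O)NCCCCC(c2ccc(F)cc2)c2ccc(F)cc2)c1`: > 20000 nM (a limit)

For the measured compounds named here, in a functional assay on MDA-MB-231 cells (Homo sapiens) for cytotoxicity, read by MTT assay, with a stated time of 48 h (a higher number here means a weaker inhibitor, a lower number a stronger inhibitor), compound 1 gives 6470 nM, the only true number in this small set. The other two compounds give no number, only (the limit of > 20000 nM in this assay, at which 2 of the 3 values shown sit).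

Compound 4 `O=C(NCCCCC(c1ccc(F)cc1)c1ccc(F)cc1)Nc1ccc([N+](=O)[O-])c(C(F)(F)F)c1` is compound 1 with trifluoromethyl in place of hydrogen on an aromatic carbon, ortho to a nitro group: trifluoromethyl in place of hydrogen on an aromatic carbon. The nitro group itself stays.

Two measured steps start from compound 1. One is an at least 3.0-fold higher number from compound 1 to compound 2 (0.49 log units; beyond the scatter), and the other is an at least 3.0-fold higher number from compound 1 to compound 3 (0.49 log units; beyond the scatter). Both remove the nitro group, and both are beyond the scatter. The remaining comparison, a step that the two limits leave unreadable from compound 2 to compound 3, adds nothing. Going by the values given here, none of these steps adds a group while keeping the nitro group, so the new change has no direct measured precedent.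

Since compound 4 keeps the nitro group that compound 1 carries at 6470 nM, a measurable value in the same region is expected in this assay, with no step beyond the scatter in either direction. The expected change is a 1.3-fold lower number from compound 1 to compound 4 (0.11 log units; within the scatter). For compound 4 the estimated value is 5000 nM, with an expected range from 1800 nM to 16000 nM.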

Compound 4, half-maximal inhibitory concentration: 4550 nM
Compound 4: middle estimate off by 1.1-fold (0.04 log units), on the high side; measured number inside the range.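

In this assay, the step of a 1.4-fold lower number from compound 1 to compound 4 (0.15 log units; within the scatter) is the only one shown that adds a group while the nitro group stays, and it lies within the scatter. On this aromatic carbon, ortho to a nitro group, the four heavy atoms of trifluoromethyl therefore leave the reading indistinguishable from the starting one, whereas the earlier readable steps showed only what happens when the nitro group goes. With this result, the two compounds that carry the nitro group, compound 1 and compound 4, both give true numbers, while compound 2 and compound 3 give only limits: the limit of > 20000 nM in this assay, at which 2 of the 4 values shown sit.

The compounds shown do not tell whether another group, such as chlorine or a methoxy group, would be tolerated on this same carbon, since trifluoromethyl is the only replacement for hydrogen seen there. They also leave open whether a nitrile or a carboxylic acid could stand in place of the nitro group and still give a measurable number, or whether a shorter or longer chain in the shared core would change the picture.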